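The source may hold more compounds than are shown below. What is called first, only, known or untested is meant among the compounds shown, and "the series" means these compounds.

Series notes. Compound 3 `O=C1C(NC2CCCC2)=CC(=O)c2c1nc1n2[C@H]2OC[C@@H](O)[C@H]2OC1` carries a cyclopentyl on the amine nitrogen; in a functional assay on HeLa cells (Homo sapiens) for inhibition, read by sulforhodamine B assay (a higher number here means a weaker inhibitor, a lower number a stronger inhibitor), compound 3 gives > 16000 nM, which is a limit of the assay and not a number. Compound 1 `COc1cccc(NC2=CC(=O)c3c(nc4n3[C@H]3OC[C@@H](O)[C@H]3OC4)C2=O)c1` in this assay gives > 8000 nM, likewise a limit. Compound 2 `CCCc1ccc(NC2=CC(=O)c3c(nc4n3[C@H]3OC[C@@H](O)[C@H]3OC4)C2=O)cc1` in this assay gives 6030 nM. Among these three the steps are an at least 1.3-fold lower number from compound 1 to compound 2 (0.12 log units; that floor lies within the scatter), a step that the two limits leave unreadable from compound 1 to compound 3 and an at least 2.6-fold higher number from compound 2 to compound 3 (0.42 log units; beyond the scatter). Compound 4 `CCOc1ccccc1NC1=CC(=O)c2c(nc3n2[C@H]2OC[C@@H](O)[C@H]2OC3)C1=O` differs from compound 3 thus: 2-ethoxyphenyl in place of cyclopentyl on an amine nitrogen. Going by the values given here, the one readable step that bears on this change, an at least 2.6-fold higher number from compound 2 to compound 3 (0.42 log units; beyond the scatter), runs the opposite way, so for compound 4 a lower number in this assay is expected, roughly an at least 2.2-fold lower number from compound 3 to compound 4 (0.35 log units; beyond the scatter). Compound 4 is therefore estimated at 7000 nM, within 3000 nM to 20000 nM.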

Compound 4, half-maximal inhibitory concentration: 8300 nM
Beside the measured number, compound 4's estimate is 1.2-fold (0.07 log units) below it, within the range that was stated.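

In this assay, 2-ethoxyphenyl on the amine nitrogen gives a 1.4-fold higher number from compound 2 to compound 4 (0.14 log units; within the scatter), so 2-ethoxyphenyl and 4-propylphenyl are not told apart at this place. Against cyclopentyl, the change gives an at least 1.9-fold lower number from compound 3 to compound 4 (0.28 log units; that floor lies within the scatter), so even this floor does not separate the two groups. Compound 3 stands at a limit of the assay and not a number: the limit of > 16000 nM in this assay, at which 1 of the 4 values shown sits.

The steps involving compound 1 cannot be read, as its value is also a limit. From the compounds shown here alone, whether a carboxylic acid or an amine on the phenyl ring would shift the number in this assay stays open.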